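The source may report more compounds than this note shows. Statements on the series, on what has been measured and on what is new or still open speak of the compounds shown alone.

In a functional assay on A549 cells (Homo sapiens) for cytotoxicity, read by MTT assay, with a stated time of 72 h (a lower number here means a stronger inhibitor, a higher number a weaker inhibitor), compound 1 `COc1cc(Nc2nc3ccccc3nc2S(=O)(=O)c2ccccc2)cc(OC)c1` gives 70 nM, the lowest of the two numbers measured. For the measured compounds named here, compound 2 `Nc1cccc(Nc2nc3ccccc3nc2S(=O)(=O)c2ccccc2)c1` gives 1590 nM, and the one measured step, a 23-fold higher number from compound 1 to compound 2 (1.36 log units; beyond the scatter), sits on the ring attached to the nitrogen, where compound 3 is unchanged. Compound 3 `COc1cc(Nc2nc3ccccc3nc2S(=O)(=O)c2ccc(C)cc2)cc(OC)c1` differs from compound 1 by methyl in place of hydrogen on an aromatic carbon, on the phenylsulfonyl side. Going by the values given here, no measured step touches that ring, and nothing in the data points to a large change there. The expected step is no change at the digits printed from compound 1 to compound 3 (within the scatter), within the scatter. Compound 3 is therefore estimated at 70 nM, with a range from 25 nM to 200 nM.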

Compound 3, half-maximal inhibitory concentration: 8060 nM
Compound 3: middle estimate off by 120-fold (2.06 log units), on the low side; the measured number lies above the stated range.
By their numbers in this assay, from the lowest: compound 1; then compound 2; then compound 3.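

For the compounds shown here, the phenylsulfonyl side, untouched by the earlier compounds, proves highly sensitive in this assay: a methyl on an aromatic carbon, para to a large group, gives a 120-fold higher number from compound 1 to compound 3 (2.06 log units; beyond the scatter). Adding just one heavy atom to this ring can therefore weaken compound 1 greatly. Nothing available explains this loss. Going by these compounds, it remains open whether the loss is specific to methyl or extends to other groups at this place, such as fluorine, methoxy or a carboxylic acid. On these data alone, the other positions on this ring also remain unexplored here.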